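A few compounds are considered here, and "the series" means these few. Any claim that something is new, unique, unknown or untested is made for them only; others in the source may bear on it.

Going by the values given here, in a physicochemical assay for solubility, in phosphate buffer, with a stated time of 18 h (on this read-out lower numbers stand for lower solubility and higher numbers for higher solubility), compound 1 `CSc1nc(C(C)(C)C)nc2nc(N)c(C#N)c(N)c12` gives 14000 nM and compound 2 `CC(C)(C)c1nc(-c2ccccc2)c2c(N)c(C#N)c(N)nc2n1` gives 4000 nM, the lower of the two numbers so far. Compound 3 `CC(C)(C)c1nc(-c2cnccn2)c2c(N)c(C#N)c(N)nc2n1` keeps the core of compound 2 but carries pyrazin-2-yl in place of phenyl on an aromatic carbon. Among the compounds with values here, only one measured step bears on this change, a 3.5-fold lower number from compound 1 to compound 2 (0.54 log units; beyond the scatter), a modest step beyond the scatter that replaces methylsulfanyl with phenyl. Within the data shown here, that step involves phenyl but not pyrazin-2-yl, so it offers only a rough guide, and no measurement yet shows what pyrazin-2-yl does here. Taking the size from it, a modest rise is expected in this assay, and the estimated change is a 2.3-fold higher number from compound 2 to compound 3 (0.35 log units; beyond the scatter). For compound 3 the estimated value is 9000 nM, with an expected range from 3000 nM to 30000 nM.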

Compound 3, solubility: 86000 nM
For compound 3 the middle estimate is 9.6-fold (0.98 log units) below the measured one, outside the stated range (above it).
By their numbers in this assay, from the lowest: compound 2; then compound 1; then compound 3.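

In this assay, the aromatic carbon next to the ring nitrogen proves highly sensitive to the ring it carries: two groups with the same count of heavy atoms, phenyl and pyrazin-2-yl, give a 22-fold higher number from compound 2 to compound 3 (1.33 log units; beyond the scatter). Placing an aromatic ring here therefore does not in itself lower the number, since compound 2 lies below compound 1 while pyrazin-2-yl gives a 6.1-fold higher number from compound 1 to compound 3 (0.79 log units; beyond the scatter). Nothing measured here accounts for the size of this change.

The compounds shown do not separate the contribution of each ring nitrogen, so a pyridin-2-yl group, with its single ring nitrogen, could fall anywhere relative to phenyl and pyrazin-2-yl. Going by these compounds, how a non-aromatic group such as morpholine or a simple amine would compare at this carbon also remains open.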